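The source may report more compounds than this note shows. Statements on the series, on what has been measured and on what is new or still open speak of the compounds shown alone.

Compound 3 `COc1ccc(NC(=O)Nc2cccc(CNc3nccnc3Cl)c2)cc1` gives 12000 nM in a functional assay on HepG2 cells (Homo sapiens) for antiproliferative activity, read by MTT assay, with a stated time of 48 h (on this read-out lower numbers stand for stronger inhibition and higher numbers for weaker inhibition), which places it second highest of the three numbers recorded so far. Its nearest neighbour is compound 2 `O=C(Nc1cccc(CNc2nccnc2Cl)c1)NC1CCCC1`, which gives 18400 nM, and the furthest is compound 1 `CCOc1ccc(NC(=O)Nc2cccc(CNc3nccnc3Cl)c2)cc1`, which gives 7050 nM; both lie within the scatter of compound 3, as the steps of a 1.5-fold lower number from compound 2 to compound 3 (0.19 log units; within the scatter) and a 1.7-fold higher number from compound 1 to compound 3 (0.23 log units; within the scatter) show. Among the measured compounds shown here, the only step beyond the scatter is a 2.6-fold higher number from compound 1 to compound 2 (0.42 log units; beyond the scatter).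

Compound 4 `COc1ccccc1NC(=O)Nc1cccc(CNc2nccnc2Cl)c1` differs from compound 3 by 2-methoxyphenyl in place of 4-methoxyphenyl on an amide-type nitrogen. For the measured compounds named here, no measured pair shifts the methoxy group around the ring, so nothing bears on this change directly. What does bear on it is that the amide-type nitrogen tolerated the swap from cyclopentyl to 4-methoxyphenyl and the ethoxy-to-methoxy trim without a step beyond the scatter. On that basis compound 4 is expected to stay close to compound 3, with a step of a 1.1-fold higher number from compound 3 to compound 4 (0.03 log units; within the scatter) that is not expected to exceed the scatter. The estimate for compound 4 is 13000 nM, between 5000 nM and 32000 nM.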

Compound 4, half-maximal inhibitory concentration: 13700 nM
For compound 4 the middle estimate is 1.1-fold (0.02 log units) below the measured one, and the stated range covers the measured number.
By their numbers in this assay, from the lowest: compounds 1, 3, 4 and 2 (each within the scatter of the next, the first and the last beyond it).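

Among the compounds shown here, compound 4 gives the first reading on where the methoxy group sits on the phenyl ring at the amide-type nitrogen in this assay, and exchanging 4-methoxyphenyl for 2-methoxyphenyl stays inside the scatter, with a 1.1-fold higher number from compound 3 to compound 4 (0.06 log units; within the scatter). The 2-methoxyphenyl group also stays within the scatter of the two other groups at this nitrogen, with a 1.3-fold lower number from compound 2 to compound 4 (0.13 log units; within the scatter) and a 1.9-fold higher number from compound 1 to compound 4 (0.29 log units; within the scatter), so it is not separated from either cyclopentyl or 4-ethoxyphenyl, although those two are separated from each other. No supporting data accompany this result to account for it.

The compounds shown leave open whether an amine or a carboxylic acid on this phenyl ring would produce a step beyond the scatter. They also leave open whether a longer chain on the ring oxygen would do so.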